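Methoxy-to-fluorine swap on the pendant phenyl of compound 2

The compounds below may be only part of what the source reports. "The series", "measured", "known", "first", "only" and "open" are said of these compounds alone.

Three compounds of this series carry a number in a functional assay on QG-56 cells (Homo sapiens) for antiproliferative activity; on this read-out lower numbers stand for stronger inhibition and higher numbers for weaker inhibition. Compound 1 `Cn1cncc1C(O)(c1ccc(C#N)cc1)c1cc2cc([N+](=O)[O-])cc(-c3ccccc3)c2o1` gives 1480 nM. Compound 2 `COc1ccc(-c2cc([N+](=O)[O-])cc3cc(C(O)(c4ccc(C#N)cc4)c4cncn4C)oc23)cc1` gives 36 nM, the lowest number of the three; its nearest neighbour, compound 3 `Cn1cncc1[C@](N)(c1ccc(C#N)cc1)c1cc2cc([N+](=O)[O-])cc(-c3ccccc3)c2o1`, gives 206 nM. Among the compounds with values here, the one single-point step measured so far is a 41-fold lower number from compound 1 to compound 2 (1.61 log units; beyond the scatter), methoxy in place of hydrogen on an aromatic carbon.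

Compound 4 `Cn1cncc1C(O)(c1ccc(C#N)cc1)c1cc2cc([N+](=O)[O-])cc(-c3cccc(F)c3)c2o1` is not yet measured. It differs from compound 2 as follows: 3-fluorophenyl in place of 4-methoxyphenyl on an aromatic carbon. Within the data shown here, the change therefore removes the 4-methoxyphenyl whose methoxy carried the whole gain seen from compound 1 to compound 2, and brings in a 3-fluorophenyl, for which no measured step exists. The expectation is that compound 4 falls back toward the number of compound 1, because of a 41-fold lower number from compound 1 to compound 2 (1.61 log units; beyond the scatter) read in reverse, tempered by the unknown contribution of the fluorine. Compound 4 is expected at 600 nM, within 150 nM to 2500 nM, a step of a 17-fold higher number from compound 2 to compound 4 (1.22 log units; beyond the scatter).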

Compound 4, half-maximal inhibitory concentration: 145 nM
Beside the measured number, compound 4's estimate is 4.1-fold (0.62 log units) above it, outside the stated range (below it).
By their numbers in this assay, from the lowest: compound 2; then compounds 4 and 3 (each within the scatter of the next); then compound 1.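

In this assay, the gain at this position is not confined to the 4-methoxyphenyl: fluoro in place of hydrogen also gives a 10-fold lower number from compound 1 to compound 4 (1.01 log units; beyond the scatter), so two different substituents on the phenyl improve on the unsubstituted compound. The gain is not equal, however, as 3-fluorophenyl in place of 4-methoxyphenyl gives a 4.0-fold higher number from compound 2 to compound 4 (0.61 log units; beyond the scatter), which returns only part of the earlier 41-fold lower number from compound 1 to compound 2 (1.61 log units; beyond the scatter). No measured evidence accounts for either gain.

Compound 2 and compound 4 differ in both the substituent and its place on the ring, so these two contributions cannot be separated here. A 4-fluorophenyl or a 3-methoxyphenyl would separate them, and an aminophenyl or a carboxyphenyl would test whether the gain extends to quite different substituents.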